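Methoxy in Place of Trifluoromethyl, Made Twice

A few compounds are considered here, and "the series" means these few. Any claim that something is new, unique, unknown or untested is made for them only; others in the source may bear on it.

Compound 1, `NC(=O)c1c(NC(=O)c2ccccc2C(F)(F)F)sc2c1CCN(C(=S)Nc1ccccc1Cl)C2`: 46900 nM
Compound 2, `COc1ccccc1C(=O)Nc1sc2c(c1C(N)=O)CCN(C(=S)Nc1ccccc1Cl)C2`: > 50000 nM, a limit of the assay
Compound 3, `NC(=O)c1c(NC(=O)c2ccccc2I)sc2c1CCN(C(=S)Nc1ccccc1C(F)(F)F)C2`: 49200 nM

In a functional assay on HeLa cells (Homo sapiens) for antiproliferative activity, with a stated time of 24 h (on this read-out higher numbers stand for weaker inhibition and lower numbers for stronger inhibition), compound 1 gives 46900 nM. For compound 2 the reading > 50000 nM is a limit of this assay and not a number. Compound 3 gives 49200 nM in this assay, a number close to that of compound 1. Compound 1 and compound 3 differ in more than one place, and the difference between their two cores is not broken down here.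

Compound 2 arises from compound 1 by methoxy in place of trifluoromethyl on an aromatic carbon. That step is an at least 1.0-fold higher number from compound 1 to compound 2 (0.02 log units; that floor lies within the scatter). Compound 4, `COc1ccccc1NC(=S)N1CCc2c(sc(NC(=O)c3ccccc3I)c2C(N)=O)C1`, has not yet been measured in this assay. It arises from compound 3 by methoxy in place of trifluoromethyl on an aromatic carbon, the same change at a place described in the same words.

Among the compounds with values here, since the one measured example of this change, an at least 1.0-fold higher number from compound 1 to compound 2 (0.02 log units; that floor lies within the scatter), stays within the scatter, and since compound 2 sits at the limit (the limit of > 50000 nM in this assay, at which 1 of the 3 values shown sits), compound 4 is expected to land near that limit as well. Compound 4 is estimated at 52000 nM in this assay, between 28000 nM and 100000 nM. The expected step is a 1.1-fold higher number from compound 3 to compound 4 (0.02 log units; within the scatter), and the assay may again report only a limit.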

Compound 4, half-maximal inhibitory concentration: > 50000 nM
Compound 4 ended at the assay's limit; the forecaster's own chance of this, stated with the estimate: 55%; the middle value is on the limit's open side.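

In this assay compound 4 gives > 50000 nM, which is a limit of the assay and not a number. The new step can therefore be read only as a floor, and that floor lies within the scatter: an at least 1.0-fold higher number from compound 3 to compound 4 (0.00 log units; that floor lies within the scatter). Methoxy in place of trifluoromethyl thus ends at the assay's limit on both cores, but this does not show that the change has the same size on each, and the comparison goes no further than this: the same change on two cores in this assay, an at least 1.0-fold higher number (0.02 log units; that floor lies within the scatter) from compound 1 to compound 2 and an at least 1.0-fold higher number (0.00 log units; that floor lies within the scatter) from compound 3 to compound 4; the limit leaves it open whether they differ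

Readings at the limit also make up much of the series shown, so little room is left for telling these compounds apart: the limit of > 50000 nM in this assay, at which 2 of the 4 values shown sit. What stays open is how this assay would respond to an amine or a carboxylic acid in place of methoxy on this aromatic carbon, and whether any such group would give a clearly lower number on either core.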